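Longer ether chain in a series held at the limit

This account rests on a few compounds, and the source may have more. Where it says the series, first, only, none or still open, it means among the compounds named here.

In an ADME assay on cells (Peritoneal macrophage, Mus musculus) for cytotoxicity, read by CCK-8 assay, with a stated time of 24 h (on this read-out higher numbers stand for lower toxicity in this test and lower numbers for higher toxicity in this test), compound 3 `COc1ccc(S(=O)(=O)N(CC(N)=O)c2ccc(N(CC(N)=O)S(=O)(=O)c3ccc(S(=O)(=O)CCOCCOCCN=C=S)cc3)c3ccccc23)cc1` stands only at a limit and not at a number (> 10000 nM). Compound 1 `COc1ccc(S(=O)(=O)N(CC(N)=O)c2ccc(N(CC(N)=O)S(=O)(=O)c3ccc(S(=O)(=O)CCCN=C=S)cc3)c3ccccc23)cc1` is also at a limit (> 10000 nM). Compound 2 `COc1ccc(S(=O)(=O)N(CC(N)=O)c2ccc(N(CC(N)=O)S(=O)(=O)c3ccc(S(=O)(=O)CCCCN=C=S)cc3)c3ccccc23)cc1` is also at a limit (> 10000 nM). Overall, the series so far shows this (the limit of > 10000 nM in this assay, at which 3 of the 3 values shown sit). Compound 4 `COc1ccc(S(=O)(=O)N(CC(N)=O)c2ccc(N(CC(N)=O)S(=O)(=O)c3ccc(S(=O)(=O)CCOCCOCCOCCN=C=S)cc3)c3ccccc23)cc1` differs from compound 3 on a saturated chain carbon, two bonds along the chain from an oxygen on a saturated carbon (a group of 6 heavy atoms (3 carbon, 1 nitrogen, 1 oxygen, 1 sulfur; no ring) in place of a group of 3 heavy atoms (1 carbon, 1 nitrogen, 1 sulfur; no ring), on a saturated chain carbon, two bonds along the chain from an oxygen on a saturated carbon). The measured steps that bear on this are (a step that the two limits leave unreadable from compound 1 to compound 2), (a step that the two limits leave unreadable from compound 1 to compound 3) and (a step that the two limits leave unreadable from compound 2 to compound 3), and none has a readable size. No step beyond the scatter and no direction is therefore expected in this assay (a step that the limit leaves unreadable from compound 3 to compound 4). The estimate for compound 4 is 20000 nM (expected range 10000 nM to 60000 nM), most likely reported as a limit again.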

Compound 4, half-maximal cytotoxic concentration: > 10000 nM
Compound 4: no number, only a limit; the forecaster's own chance of this, stated with the estimate: 90%; the middle value lies beyond the limit too.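

Compound 4 joins compound 1, compound 2 and compound 3 at a limit in this assay, so no step among them can be read: the limit of > 10000 nM in this assay, at which 4 of the 4 values shown sit.

On these data alone, how far each compound lies beyond that limit, and whether chain length matters there, stays open.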